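This account rests on a few compounds, and the source may have more. Where it says the series, first, only, none or still open, it means among the compounds named here.

In a functional assay on A2780 cells (Homo sapiens) for cytotoxicity, read by MTT assay, with a stated time of 72 h (a higher number here means a weaker inhibitor, a lower number a stronger inhibitor), compound 2 (`CN(C)c1ccc(C(=O)N(CCCCCC(=O)Nc2cc(F)ccc2N)CC(=O)NCc2ccccc2)cc1`) gives 25900 nM and lies within the scatter of compound 1 (`Cc1cc(C)cc(C(=O)N(CCCCCC(=O)Nc2ccccc2N)CC(=O)NC2CCCCC2)c1`) at 42000 nM while reading a higher number than compound 3 (`Cc1ccc(CNC(=O)CN(CCCCCC(=O)Nc2ccccc2N)C(=O)c2cc(C)cc(C)c2)cc1`) at 9800 nM in the same test. Compound 4 (`CN(C)c1ccc(C(=O)N(CCCCCC(=O)Nc2ccccc2N)CC(=O)NCc2ccccc2)cc1`) differs from compound 2 by hydrogen in place of fluoro on an aromatic carbon with hydrogen in place of fluoro on an aromatic carbon. Among the measured compounds shown here, the only measured step is a 4.3-fold lower number from compound 1 to compound 3 (0.63 log units; beyond the scatter) and it concerns a different place, so no measured step touches the fluoro. In this assay no step beyond the scatter is therefore expected. The estimate means a 1.3-fold lower number from compound 2 to compound 4 (0.11 log units; within the scatter) as the expected step. For compound 4 the expected value is 20000 nM with an estimated range from 9000 nM to 42000 nM overall.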

Compound 4, half-maximal inhibitory concentration: 18500 nM
Compound 4: the middle estimate sits 1.1-fold (0.03 log units) above what was measured; low and high end bracket the measured number.
By their numbers in this assay, from the lowest: compounds 3, 4, 2 and 1 (each within the scatter of the next, the first and the last beyond it).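

In this assay, hydrogen in place of fluoro on this aromatic carbon, para to an amino group, gives a 1.4-fold lower number from compound 2 to compound 4 (0.15 log units; within the scatter), so this change on the 2-amino-5-fluorophenyl group stays within the scatter. Among the compounds shown here, this is the first measured step at this position, as the earlier step concerned a different place. No evidence bearing on the cause of this result is available.

From the compounds shown here alone, whether a chloro, methoxy or amino group on the same carbon would also stay within the scatter remains open. So does whether the fluoro would read the same alongside the cyclohexyl group of compound 1.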